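The compounds below may be only part of what the source reports. "The series", "measured", "known", "first", "only" and "open" are said of these compounds alone.

Compounds measured so far:
compound 1, `N#CC1=C(N)Oc2c(c3nc4ccccc4nc3c3ccccc23)C12C(=O)N(Cc1cnnn1-c1ccc(Cl)cc1)c1ccccc12`, > 50000 nM
compound 2, `Cc1ccc(Cl)cc1-n1nncc1CN1C(=O)C2(C(C#N)=C(N)Oc3c2c2nc4ccccc4nc2c2ccccc32)c2ccccc21`, > 50000 nM
compound 3, `N#CC1=C(N)Oc2c(N)cc3nc4ccccc4nc3c2C12C(=O)N(Cc1cnnn1-c1cccc(C(F)(F)F)c1)c1ccccc12`, 5400 nM

In a functional assay on A549 cells (Homo sapiens) for antiproliferative activity, read by MTT assay, with a stated time of 48 h (on this read-out lower numbers stand for stronger inhibition and higher numbers for weaker inhibition), compound 1 reaches only a limit of the assay, > 50000 nM. Compound 2 likewise reaches only a limit, > 50000 nM. The step that the two limits leave unreadable from compound 1 to compound 2 therefore cannot be read. Going by the values given here, compound 3 gives the one number, 5400 nM. It stands alone as a measured value; the other two compounds sit at a limit of the assay, as the limit of > 50000 nM in this assay, at which 2 of the 3 values shown sit, shows.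

Compound 4, `COc1cc(-n2nncc2CN2C(=O)C3(C(C#N)=C(N)Oc4c(N)cc5nc6ccccc6nc5c43)c3ccccc32)c(OC)cc1Cl`, has not yet been measured. It differs from compound 3 by 4-chloro-2,5-dimethoxyphenyl in place of 3-(trifluoromethyl)phenyl on an aromatic nitrogen. Among the compounds with values here, no measured step carries a readable size, and none touches this change on the aromatic nitrogen, so nothing here points in either direction. The estimate for compound 4 in this assay is 6500 nM, expected to lie between 2000 nM and 25000 nM. The step this implies, a 1.2-fold higher number from compound 3 to compound 4 (0.08 log units; within the scatter), is expected to stay within the usual scatter, with a real chance that the assay returns only a limit, as it did for compound 1 and compound 2.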

Compound 4, half-maximal inhibitory concentration: > 50000 nM
Compound 4 gave a limit, no number; the forecaster's own chance of this, stated with the estimate: 25%; at least 7.6-fold (0.88 log units) between middle value and limit.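

In this assay, going by these compounds alone, this is the first step whose size can be read: putting 4-chloro-2,5-dimethoxyphenyl in place of 3-(trifluoromethyl)phenyl on the aromatic nitrogen gives an at least 9.2-fold higher number from compound 3 to compound 4 (0.96 log units; beyond the scatter), which lies beyond the scatter. The group carried on this nitrogen therefore matters to the read-out, since this one change, with the rest of the structure held constant, separates a compound with a measured value from one without. Compound 4 gives only a limit, not a number, and this places it with the other compounds at the same limit: the limit of > 50000 nM in this assay, at which 3 of the 4 values shown sit.

The size of the loss remains unknown beyond what the limit allows, the step between the two compounds that differ in one place at this limit cannot be read, and the exchange alters the chlorine, the two methoxy groups and the trifluoromethyl group together, so the compounds shown do not assign the change to any one of them. They also leave open how the 3-chlorophenyl or 3-methoxyphenyl group, a pyridine ring or a simple alkyl chain on this nitrogen would read out on the core of compound 3.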